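The source may report more compounds than this note shows. Statements on the series, on what has been measured and on what is new or still open speak of the compounds shown alone.

Measured compounds:
- compound 1 `C=CCn1c(=O)/c(=C\c2ccccc2Cl)[nH]c(=O)/c1=C\c1ccccc1OC`: 4600 nM
- compound 2 `C=CCn1c(=O)/c(=C\c2cccc(Cl)c2Cl)[nH]c(=O)/c1=C\c1ccccc1OC`: 2200 nM

Both numbers come from a functional assay on BGC-823 cells (Homo sapiens) for cytotoxicity, read by CCK-8 assay, with a stated time of 72 h; on this read-out lower numbers stand for stronger inhibition and higher numbers for weaker inhibition. Going by the values given here, compound 2 holds the lowest of the two numbers; the only other compound is compound 1, and the step of a 2.1-fold lower number from compound 1 to compound 2 (0.32 log units; beyond the scatter) is modest but beyond the scatter. Compound 3 `C=CCn1c(=O)/c(=C\c2cc(Br)ccc2F)[nH]c(=O)/c1=C\c1ccccc1OC` is not yet measured. It differs from compound 2 by 5-bromo-2-fluorophenyl in place of 2,3-dichlorophenyl on a double-bonded chain carbon bound to an aromatic carbon. Among the compounds with values here, no measured step swaps one halogenated phenyl for another of this kind; the single step in hand, a 2.1-fold lower number from compound 1 to compound 2 (0.32 log units; beyond the scatter), concerns adding a chloro and bears on the new compound only loosely, since compound 3 keeps two halogens on that ring as compound 2 does but of different kind and placement. Little movement is therefore expected in this assay, with a step of a 1.4-fold higher number from compound 2 to compound 3 (0.13 log units; within the scatter) that may fall within the scatter in either direction. Compound 3 is estimated at 3000 nM, range 1200 nM to 8000 nM.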

Compound 3, half-maximal inhibitory concentration: "not active" (no number reported)
Compound 3: no number reported; no gap can be computed for the estimate.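

In this assay, going by these compounds alone, compound 3 is reported as "not active" with no number, so no step from compound 2 can be read. No available evidence bears on this result. The compounds shown leave open how far 5-bromo-2-fluorophenyl in place of 2,3-dichlorophenyl moves the number.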